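The source may hold more compounds than are shown below. What is called first, only, known or untested is meant among the compounds shown, and "the series" means these compounds.

Measured in an ADME assay (liver, Mus musculus) for metabolic stability, read by LC-MS, using microsomes, tested at 1 uM; a higher number here means that the compound lasts longer, a lower number that the compound disappears faster:
Compound 1 `C/C(=N/c1ccnc2cc(Cl)ccc12)NCCCCN1CCCCC1`: > 1 h, which is a limit of the assay.
Compound 2 `CCN(CC)CCN/C(C)=N\c1ccnc2cc(Cl)ccc12`: 0.3 h.

Going by the values given here, compound 2, at 0.3 h, holds the only actual number, and the other result stands at the limit of > 1 h in this assay, at which 1 of the 2 values shown sits. Compound 3 `CCN(CC)CCCCN/C(C)=N\c1ccnc2cc(Cl)ccc12` differs from it by 2-(diethylamino)ethyl in place of diethylamino on a saturated chain carbon, two bonds along the chain from an amine nitrogen, with 2-(diethylamino)ethyl in place of diethylamino on a saturated chain carbon. Among the compounds with values here, one measured step bears on this: an at least 3.3-fold lower number from compound 1 to compound 2 (0.52 log units; beyond the scatter). That step replaced a longer group with diethylamino at the same place, so the reverse change is expected to raise the number modestly. The expected step is a 2.3-fold higher number from compound 2 to compound 3 (0.37 log units; beyond the scatter). For compound 3 the estimated half-life is 0.7 h, with an expected range of 0.3 h to 1.5 h.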

Compound 3, half-life: > 1 h
Compound 3 gave a limit, no number; the forecaster's own chance of this, stated with the estimate: 25%; at least 1.4-fold (0.15 log units) between middle value and limit.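

In this assay the change to 2-(diethylamino)ethyl alone gives an at least 3.3-fold higher number from compound 2 to compound 3 (0.52 log units; beyond the scatter) with diethylamino still at the chain end, so the longer chain reaches the limit without piperidin-1-yl. Compound 1 and compound 3 both stand at a limit of the assay, and the step between them cannot be read. The top of the read-out is now reached twice: the limit of > 1 h in this assay, at which 2 of the 3 values shown sit.

Going by these compounds, how far the half-life rises with chain length remains open. So does whether a morpholin-4-yl group at the chain end would behave like diethylamino.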